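The compounds below may be only part of what the source reports. "The series", "measured", "known", "first", "only" and "open" are said of these compounds alone.

Measured so far:
- compound 1, `CSCCCON1C(=O)[C@@H](NC(=O)OCCCCC2CCCCC2)[C@@H]1C`: 167 nM
- compound 2, `C[C@H]1[C@H](NC(=O)OCCCCC2CCCCC2)C(=O)N1OCCCCc1ccccc1`: 1240 nM

In an assay on HEK293 cells for inhibition of N-acylethanolamine-hydrolyzing acid amidase (Homo sapiens), read by fluorescence, with stated times of 10 min and 50 min (a lower number here means a stronger inhibitor, a higher number a weaker inhibitor), compound 2 stands highest of the two numbers; the nearest is compound 1, and the step of a 7.4-fold higher number from compound 1 to compound 2 (0.87 log units; beyond the scatter) lies beyond the scatter. Compound 3, `C[C@H]1[C@H](NC(=O)OCCCCC2CCCCC2)C(=O)N1Oc1ccc(S(C)(=O)=O)cc1`, is not yet measured. It differs from compound 2 as follows: 4-(methylsulfonyl)phenyl in place of 4-phenylbutyl on an oxygen. Among the measured compounds shown here, the only measured step, from compound 1 to compound 2, also alters the group carried by this same oxygen, and it moved the number by a 7.4-fold higher number from compound 1 to compound 2 (0.87 log units; beyond the scatter). That step, however, exchanges one saturated chain for another with a benzyl ending, whereas here the whole 4-phenylbutyl gives way to a 4-(methylsulfonyl)phenyl placed directly on the oxygen. For the measured compounds named here, no measured pair covers such an exchange, so the direction of a 2.5-fold lower number from compound 2 to compound 3 (0.39 log units; beyond the scatter) is expected only loosely, with the single step as the sole guide to its possible size. For compound 3 the estimate in this assay is 500 nM, with a range from 80 nM to 3000 nM.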

Compound 3, half-maximal inhibitory concentration: 6 nM
Compound 3: the middle estimate sits 83-fold (1.92 log units) above what was measured; the whole stated range lies above it.
By their numbers in this assay, from the lowest: compound 3; then compound 1; then compound 2.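

In this assay, the group on the oxygen whose other neighbour is the amide-type nitrogen in a ring controls the number over a far wider span than the earlier pair suggested: the change gives a 210-fold lower number from compound 2 to compound 3 (2.32 log units; beyond the scatter), well beyond the earlier 7.4-fold higher number from compound 1 to compound 2 (0.87 log units; beyond the scatter). Compound 3 also stands clear of the better of the two chain-ended compounds, with a 28-fold lower number from compound 1 to compound 3 (1.44 log units; beyond the scatter), so 4-(methylsulfonyl)phenyl on this oxygen outperforms both 4-phenylbutyl and 3-(methylsulfanyl)propyl here. Since 4-phenylbutyl and 4-(methylsulfonyl)phenyl both count 10 heavy atoms and one six-membered aromatic ring, neither group size nor the presence of that ring separates compound 2 from compound 3, and nothing at hand explains the size of this step.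

Going by these compounds, the step from compound 2 to compound 3 changes the butyl chain and the methylsulfonyl group together, so their separate shares remain open; a plain phenyl on this oxygen, or 4-(methylsulfonyl)phenyl carried on a butyl chain, would divide them. Also open, on these data alone, is whether the methylsulfonyl group itself is needed, or whether a nitrile or a carboxylic acid in its place would give a similar number.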